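The source may report more compounds than this note shows. Statements on the series, on what has been measured and on what is new or still open speak of the compounds shown alone.

Measured in an assay for inhibition of Fatty-acid amide hydrolase 1 (Rattus norvegicus); on this read-out higher numbers stand for weaker inhibition and lower numbers for stronger inhibition:
compound 1, `COC(=O)c1cnc(C(=O)CCc2ccc(Oc3ccccc3)cc2)o1`, gives 1.7 nM;
compound 2, `O=C(O)c1ccc(-c2cnc(C(=O)CCc3ccc(Oc4ccccc4)cc3)o2)nc1`, gives 33 nM;
compound 3, `CN(C)C(=O)c1cnc(C(=O)CCc2ccc(-c3ccccc3)cc2)o1`, gives 3 nM.

Compound 3 stands second highest of these three numbers. Its nearest is compound 1, whose number is lower but within the scatter, so the two cannot be ordered; compound 2 lies well beyond the scatter with a higher number. Within the data shown here, the single measured step, a 19-fold higher number from compound 1 to compound 2 (1.29 log units; beyond the scatter), concerns a change at the other end of the shared core and does not bear on the step from compound 3 to compound 4. Compound 4, `CN(C)C(=O)c1cnc(C(=O)CCc2ccc(Oc3ccccc3)cc2)o1`, differs from compound 3 by phenoxy in place of phenyl on an aromatic carbon. Among the measured compounds shown here, with no measured step touching this change, no step beyond the scatter is expected: a 1.2-fold lower number from compound 3 to compound 4 (0.08 log units; within the scatter). Compound 4 is therefore estimated at 2.5 nM, within the range 0.9 nM to 7 nM.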

Compound 4, inhibition constant: 5.4 nM
Compound 4: the middle estimate sits 2.2-fold (0.33 log units) below what was measured; measured number inside the range.
By their numbers in this assay, from the lowest: compounds 1, 3 and 4 (each within the scatter of the next, the first and the last beyond it); then compound 2.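

In this assay, phenoxy in place of phenyl on the aromatic carbon para to a large group gives a 1.8-fold higher number from compound 3 to compound 4 (0.26 log units; within the scatter), so this added oxygen leaves no readable change in inhibition. With phenoxy held in place, dimethylamino in place of methoxy on the carbonyl carbon gives a 3.2-fold higher number from compound 1 to compound 4 (0.50 log units; beyond the scatter), while dimethylcarbamoyl in place of 5-carboxypyridin-2-yl gives a 6.1-fold lower number from compound 2 to compound 4 (0.79 log units; beyond the scatter). No measurement offered here explains these steps. Going by these compounds, whether a benzyloxy group or an amine at the phenoxy position would keep this level of inhibition stays open.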